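The source may report more compounds than this note shows. Statements on the series, on what has been measured and on what is new or still open speak of the compounds shown alone.

Compound 1 (`O=C(NCc1ccccc1)c1cccnc1Oc1ccc(F)cc1`) and compound 2 (`O=C(Nc1ccccc1)c1cccnc1Oc1ccc(F)cc1`) share one core and differ only at the amide nitrogen. In a functional assay on the whole organism with Mus musculus as the target (on this read-out higher numbers stand for an effect only at larger amounts of compound and lower numbers for an effect already at smaller amounts), compound 1 gives 0.01 mg/kg, and in this assay compound 2 gives 0.001 mg/kg. Among these two numbers compound 1 stands highest; the single measured step, a 10-fold lower number from compound 1 to compound 2 (1.00 log units; beyond the scatter), arises from phenyl in place of benzyl on an amide-type nitrogen.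

Compound 3 (`N#Cc1cccc(Oc2ncccc2C(=O)NCc2ccccc2)c1`) keeps the benzyl amide of compound 1 and changes the other end: 3-cyanophenyl in place of 4-fluorophenyl on an oxygen on an aromatic ring. Among the compounds with values here, no measured step touches this oxygen-linked ring; the one step that is known concerns the amide side and therefore gives no guidance here. With nothing to point either way, the expectation for compound 3 in this assay is a step of no more than the usual scatter in either direction, namely no change at the digits printed from compound 1 to compound 3 (within the scatter). Compound 3 is thus estimated at 0.01 mg/kg, with a range from 0.002 mg/kg to 0.05 mg/kg, and the measurement will show whether the 3-cyanophenyl group moves the minimum effective dose at all.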

Compound 3, minimum effective dose: 0.1 mg/kg
The estimate for compound 3 lay 10-fold (1.00 log units) below the measured number; the whole stated range lies below it.
By their numbers in this assay, from the lowest: compound 2; then compound 1; then compound 3.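

Swapping 4-fluorophenyl for 3-cyanophenyl on the oxygen gives a 10-fold higher number from compound 1 to compound 3 (1.00 log units; beyond the scatter) in this assay and so shows that this end of the molecule, which no earlier step had touched, also shifts the minimum effective dose. This step has the same printed size as a 10-fold lower number from compound 1 to compound 2 (1.00 log units; beyond the scatter) but runs the opposite way, so that changes at either end of the shared core can move the number substantially in this small set. The two groups differ both in the substituent and in the ring number in their names, so this single step cannot separate the loss of fluorine, the entry of the nitrile and the change of ring position, and no independent data on these compounds bear on the result.

From the compounds shown here alone, it remains open whether 3-cyanophenyl would raise the number to a similar extent on the phenyl amide of compound 2, which would show whether the two ends act independently. Also unresolved is how 3-fluorophenyl, 4-cyanophenyl or unsubstituted phenyl on the same oxygen would compare, and these three groups could separate the contribution of the substituent from that of its ring position.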